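A few compounds are considered here, and "the series" means these few. Any claim that something is new, unique, unknown or untested is made for them only; others in the source may bear on it.

Compound 1 `COc1ccc(/C=C/C(=O)/C(C)=C/c2ccc(OC)cc2)cc1`: 34100 nM
Compound 2 `COc1ccc(/C=C(\C)C(=O)/C=C/c2ccc(N(C)C)cc2)cc1`: 36200 nM

In an ADME assay on J774.A1 cells (Mus musculus) for cytotoxicity, read by MTT assay, with a stated time of 48 h (on this read-out higher numbers stand for lower toxicity in this test and lower numbers for higher toxicity in this test), compound 2 gives 36200 nM, within the scatter of compound 1 at 34100 nM. Compound 3 `C/C(=C\c1ccc([N+](=O)[O-])cc1)C(=O)/C=C/c1ccc(N(C)C)cc1` has nitro in place of methoxy on an aromatic carbon, para to a large group (nitro in place of methoxy on an aromatic carbon). Among the measured compounds shown here, the only measured step, a 1.1-fold higher number from compound 1 to compound 2 (0.03 log units; within the scatter), also replaces methoxy on an aromatic carbon, with dimethylamino, and it lies within the scatter. For the measured compounds named here, no measured compound carries nitro, so this one step is weak guidance. The expected change is no more than the scatter, a 1.2-fold lower number from compound 2 to compound 3 (0.08 log units; within the scatter). The estimated value for compound 3 is 30000 nM, with an expected range of 12000 nM to 70000 nM.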

Compound 3, half-maximal cytotoxic concentration: 24700 nM
Compound 3: the middle estimate sits 1.2-fold (0.08 log units) above what was measured; measured number inside the range.
By their numbers in this assay, from the lowest: compounds 3, 1 and 2 (each within the scatter of the next).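

In this assay, the step of a 1.5-fold lower number from compound 2 to compound 3 (0.17 log units; within the scatter) stays within the scatter when nitro replaces the methoxy that remains in compound 2, on an aromatic carbon, para to a large group. A second methoxy replacement therefore leaves the number within the scatter, now with nitro, and compound 3 carries no methoxy at all. No evidence bears on why this change leaves the number within the scatter.

On these data alone, whether an amine or a carboxylic acid at this place would also stay within the scatter remains open. Also open, as far as these compounds go, is how a halogen such as chlorine would compare with nitro on this core.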